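A few compounds are considered here, and "the series" means these few. Any claim that something is new, unique, unknown or untested is made for them only; others in the source may bear on it.

Measured compounds:
compound 1 `Cc1ccc(OCC(=O)N(Cc2cccs2)c2cnn(C)c2)cc1` gives 63000 nM in an assay on HEK293 cells for agonist activity at transient receptor potential cation channel subfamily M member 8 (Homo sapiens), read by fluorescence and calcium flux, with a stated time of 15 min; on this read-out lower numbers stand for an effect already at smaller amounts and higher numbers for an effect only at larger amounts of compound;
compound 2 `CCc1ccc(OCC(=O)N(CC)Cc2cccs2)cc1` gives 67 nM;
compound 3 `CCN(Cc1cccs1)C(=O)COc1ccc(CO)cc1` gives 21900 nM.

Compound 1 stands highest of the three, with compound 3 nearest and compound 2 furthest. Compound 4 `COCCN(Cc1cccs1)C(=O)COc1ccc(C)cc1` differs from compound 1 in one place: 2-methoxyethyl in place of 1-methyl-1H-pyrazol-4-yl on an amide-type nitrogen. Among the measured compounds shown here, no measured step touches the amide-type nitrogen; the only measured step, a 330-fold higher number from compound 2 to compound 3 (2.51 log units; beyond the scatter), concerns the aryl substituent and does not bear on this change. Compound 2, which carries a small alkyl group on that nitrogen, gives a far lower number than compound 1, and they differ in two places. A large step downward is therefore expected, a 160-fold lower number from compound 1 to compound 4 (2.20 log units; beyond the scatter). Compound 4 is estimated at 400 nM, within 60 nM to 3000 nM.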

Compound 4, half-maximal effective concentration: 400 nM
Compound 4: middle estimate and measured number agree at the digits printed; the range from low to high includes it.
By their numbers in this assay, from the lowest: compound 2; then compound 4; then compound 3; then compound 1.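

In this assay, 2-methoxyethyl in place of 1-methyl-1H-pyrazol-4-yl on the amide-type nitrogen gives a 160-fold lower number from compound 1 to compound 4 (2.20 log units; beyond the scatter). This shows that the amide-type nitrogen, like the aryl substituent, is a place where a single change moves the number far beyond the scatter, and that a ring on this nitrogen is not required for a number well below that of compound 1. No measurement shown here explains this drop.

The compounds shown leave open how a longer chain such as 3-methoxypropyl, or a 2-aminoethyl group, would fare on this nitrogen.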